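Extra chloro on two acid cores against NOTUM

The source may hold more compounds than are shown below. What is called first, only, known or untested is meant among the compounds shown, and "the series" means these compounds.

Compound 1 `Cc1cc(C(=O)O)c(C)n1-c1ccccc1Cl` and compound 2 `Cc1cc(C(=O)O)c(C)n1-c1c(Cl)cccc1Cl` share one core; compound 3 `O=C(O)C1CCN(c2ccc(Cl)c(Cl)c2)C1` carries another, and compound 4 `O=C(O)C1CCN(c2ccc(Cl)c(Cl)c2Cl)C1` is its unmeasured partner. In an assay on cells for inhibition of Palmitoleoyl-protein carboxylesterase NOTUM variant C330S (Homo sapiens), read by fluorescence, with a stated time of 40 min (a higher number here means a weaker inhibitor, a lower number a stronger inhibitor), compound 1 gives 2300 nM. Compound 2 gives 2300 nM in this assay, so the step of no change at the digits printed from compound 1 to compound 2 (within the scatter) is flat; the change made there is chloro in place of hydrogen on an aromatic carbon. Compound 3 gives 1200 nM in this assay, a value within the scatter of compound 1 and of compound 2. The difference between the core of compound 3 and the core of compound 1 is not broken down here.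

The change from compound 3 to compound 4 is chloro in place of hydrogen on an aromatic carbon. It is the same kind of change as from compound 1 to compound 2, but the surroundings differ: in compound 2 the entering chloro sits ortho to a large group and meta to a chloro group, whereas in compound 4 it sits ortho to a chloro group, ortho to a group of 8 heavy atoms and meta to a chloro group.

The step of no change at the digits printed from compound 3 to compound 4 (within the scatter) is expected to be flat, resting on no change at the digits printed from compound 1 to compound 2 (within the scatter), which stayed within the scatter. Compound 4 is therefore estimated at 1200 nM, expected between 500 nM and 3000 nM.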

Compound 4, half-maximal inhibitory concentration: 600 nM
For compound 4 the middle estimate is 2.0-fold (0.30 log units) above the measured one; the measured number falls inside the stated range.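

In this assay the new step is a 2.0-fold lower number from compound 3 to compound 4 (0.30 log units; within the scatter) and it can be set beside the same change on the other core: the same change on two cores in this assay, no change at the digits printed (within the scatter) from compound 1 to compound 2 and a 2.0-fold lower number (0.30 log units; within the scatter) from compound 3 to compound 4, 2.0-fold (0.30 log units) apart, within the scatter of two such steps. On these two cores, chloro in place of hydrogen on an aromatic carbon therefore carries across with no difference that can be told from the scatter, and neither step on its own shows a real shift in the number. This rests on a single pair per core, with the entering chloro in different surroundings, so it does not show that the change would stay flat on further cores or at other places on the aromatic ring.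

The compounds shown leave open whether a different group at the same place, such as methyl or methoxy, would move the number beyond the scatter. They also leave open whether this flat response to chloro would hold with a primary amide in place of the carboxylic acid.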